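Furan-3-yl in place of the ring end group

The source may report more compounds than this note shows. Statements on the series, on what has been measured and on what is new or still open speak of the compounds shown alone.

In a functional assay on K562 cells (Homo sapiens) for cytotoxicity, read by MTT assay (a lower number here means that less compound is tolerated, a higher number that more compound is tolerated), compound 3 `CC1=C(O)/C(=C/[C@H](C)CC/C=C(/C)CC/C=C(/C)CCCC2=CC(=O)OC2O)OC1=O` gives > 100 ug/mL, which is a limit and not a number. Compound 2 `CC1=C(O)/C(=C/[C@H](C)CC/C=C(/C)CC/C=C(/C)CCCC2=CC(O)OC2=O)OC1=O` gives > 100 ug/mL, also a limit. Compound 1 `C/C(=C/CC[C@@H](C)CC(=O)O)CC/C=C(/C)CCCc1ccoc1` gives > 100 ug/mL, again a limit. Going by the values given here, all measurements so far therefore stand at the limit of > 100 ug/mL in this assay, at which 3 of the 3 values shown sit, and no compound goes against this.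

Compound 4 `CC1=C(O)/C(=C/[C@H](C)CC/C=C(/C)CC/C=C(/C)CCCc2ccoc2)OC1=O` differs from compound 3 as follows: a group of 5 heavy atoms (4 carbon, 1 oxygen; one five-membered aromatic ring with 1 hetero atom) in place of a group of 7 heavy atoms (4 carbon, 3 oxygen; one five-membered non-aromatic ring with 1 hetero atom), on a saturated chain carbon, three bonds along the chain from a double-bonded chain carbon. The change takes place on a saturated chain carbon, three bonds along the chain from a double-bonded chain carbon. Among the compounds with values here, the only measured step that bears on it is a step that the two limits leave unreadable from compound 2 to compound 3, which concerns the same position but has no readable size. It therefore offers no size or direction to carry over, and another limit in this assay is the most likely outcome.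

The expected size is a number no higher from compound 3 to compound 4 (the limit leaves the size open), with no direction that can be read. For compound 4 the estimated value is 100 ug/mL, with an expected range of 30 ug/mL to 200 ug/mL.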

Compound 4, concentration lethal to 50% of the cells: 62 ug/mL
Estimate against measurement, compound 4: 1.6-fold (0.21 log units) above, and the stated range covers the measured number.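

Going by these compounds alone, with furan-3-yl as the end group, compound 4 gives 62 ug/mL in this assay, the only value that is a number. The other compounds all sit at one limit: the limit of > 100 ug/mL in this assay, at which 3 of the 4 values shown sit. The readable steps are an at least 1.6-fold lower number from compound 3 to compound 4 (0.20 log units; that floor lies within the scatter), an at least 1.6-fold lower number from compound 2 to compound 4 (0.20 log units; that floor lies within the scatter) and an at least 1.6-fold lower number from compound 1 to compound 4 (0.20 log units; that floor lies within the scatter); each is a floor only, and each floor lies within the scatter. A number can therefore be read with this group on the saturated chain carbon, but no step beyond the scatter is shown, and the step between the two non-aromatic ring end groups stays unreadable.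

As far as these compounds go, how far compounds 1, 2 and 3 really lie from compound 4 stays unknown. Also open, from the compounds shown here alone, is how an amine in place of furan-3-yl, or a longer chain carrying it, would read in this assay.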